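Swapping methoxy for nitro on compound 3

The source may report more compounds than this note shows. Statements on the series, on what has been measured and on what is new or still open speak of the compounds shown alone.

Measured in a functional assay on HepG2 cells (Homo sapiens) for inhibition, read by MTT assay, with a stated time of 72 h; on this read-out lower numbers stand for stronger inhibition and higher numbers for weaker inhibition:
compound 1 `COc1ccc(/C=C/C(=O)c2c(OC)cc(O)c(CC=C(C)C)c2O)cc1` gives 32400 nM
compound 2 `COc1cc(O)c(CC=C(C)C)c(O)c1C(=O)/C=C/c1ccc([N+](=O)[O-])cc1` gives 12400 nM
compound 3 `COc1ccc(/C=C/C(=O)c2c(O)cc(O)cc2OC)cc1` gives 18100 nM

The value of compound 3 lies within the usual scatter of the values of both other compounds, so its place among the three is not firm. Compound 4 `COc1cc(O)cc(O)c1C(=O)/C=C/c1ccc([N+](=O)[O-])cc1` differs from compound 3 in one place: nitro in place of methoxy on an aromatic carbon, para to a large group (nitro in place of methoxy on an aromatic carbon).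

The same swap has been measured once, as a 2.6-fold lower number from compound 1 to compound 2 (0.42 log units; beyond the scatter). That pair carries a 3-methylbut-2-en-1-yl group, which compound 3 lacks. Taking that group away made no clear difference, as shown by a 1.8-fold lower number from compound 1 to compound 3 (0.25 log units; within the scatter). The earlier swap may therefore carry over, though a single modest step is thin support. A step of similar or somewhat smaller size towards a lower number seems reasonable in this assay. The expected change is a 2.3-fold lower number from compound 3 to compound 4 (0.35 log units; beyond the scatter). The estimate for compound 4 is 8000 nM, with an expected range from 3500 nM to 18000 nM.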

Compound 4, half-maximal inhibitory concentration: 41000 nM
For compound 4 the middle estimate is 5.1-fold (0.71 log units) below the measured one; measured number outside the range, above it.
By their numbers in this assay, from the lowest: compounds 2, 3, 1 and 4 (each within the scatter of the next, the first and the last beyond it).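

In this assay, nitro in place of methoxy gives a 2.3-fold higher number from compound 3 to compound 4 (0.36 log units; beyond the scatter), so without the 3-methylbut-2-en-1-yl group the swap points the opposite way, and one core cannot predict the other: the same change on two cores in this assay, a 2.6-fold lower number (0.42 log units; beyond the scatter) from compound 1 to compound 2 and a 2.3-fold higher number (0.36 log units; beyond the scatter) from compound 3 to compound 4, 5.9-fold (0.77 log units) apart, beyond the scatter of two such steps

The 3-methylbut-2-en-1-yl group also counts for more once nitro is present, since taking it away then gives a 3.3-fold higher number from compound 2 to compound 4 (0.52 log units; beyond the scatter), whereas its removal made no clear difference with methoxy: the same change on two cores in this assay, a 1.8-fold lower number (0.25 log units; within the scatter) from compound 1 to compound 3 and a 3.3-fold higher number (0.52 log units; beyond the scatter) from compound 2 to compound 4, 5.9-fold (0.77 log units) apart, beyond the scatter of two such steps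

Among these four compounds, then, the two changes do not simply add up, and the effect of each depends on the other.

Going by these compounds, what remains open is whether other groups on this aromatic carbon, such as an amine or a carboxylic acid, would also depend on the 3-methylbut-2-en-1-yl group. It is also unknown whether a shorter or longer chain in its place would behave the same way, and these compounds do not explain the dependence.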